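The compounds below may be only part of what the source reports. "The series", "measured", "known", "first", "only" and "open" are said of these compounds alone.

Measured in an ADME assay on cells (Fibroblast, Gallus gallus) for cytotoxicity, read by CCK-8 assay, with a stated time of 48 h; a higher number here means that more compound is tolerated, a lower number that less compound is tolerated:
Compound 1 `CCC(CC)O[C@@H]1C=C(C(=O)O)C[C@H](NCc2ccc(Cc3ccccc3)cc2)[C@H]1NC(C)=O`: > 200000 nM
Compound 2 `CCC(CC)O[C@@H]1C=C(C(=O)O)C[C@H](NCc2ccc(SC3CCCC3)cc2)[C@H]1NC(C)=O`: > 200000 nM

Compound 2 gives > 200000 nM, and this is a limit of the assay, not a number. Compound 1 gives > 200000 nM, which is also a limit. Compound 2 therefore has no exact value, and the two compounds cannot be ranked. What the data show so far is the limit of > 200000 nM in this assay, at which 2 of the 2 values shown sit.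

Compound 3 `CCC(CC)O[C@@H]1C=C(C(=O)O)C[C@H](NCc2ccc(SC3CCCCC3)cc2)[C@H]1NC(C)=O` keeps the rest of compound 2 and carries cyclohexyl in place of cyclopentyl on a sulfur.

Going by the values given here, only one measured step bears on this change, and only loosely: a step that the two limits leave unreadable from compound 1 to compound 2. It replaced benzyl on an aromatic carbon with cyclopentylsulfanyl, so it also changed the group that is changing now. Its size cannot be read, so it offers no measured effect to carry over. With both known values at the limit, no step beyond the usual scatter is expected in this assay, in either direction, and compound 3 will most likely be reported as a limit too.

The estimated step is a step that the limit leaves unreadable from compound 2 to compound 3.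

For compound 3 the expected value is 220000 nM, with an estimated range from 120000 nM to 400000 nM.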

Compound 3, half-maximal cytotoxic concentration: > 200000 nM
Compound 3: no number, only a limit (the forecaster's own chance of this, stated with the estimate: 85%); the middle value is on the limit's open side.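

In this assay compound 3 gives > 200000 nM, which is a limit of the assay, not a number. Going by these compounds alone, no step among compound 1, compound 2 and compound 3 can therefore be read. Whether benzyl, cyclopentylsulfanyl and cyclohexylsulfanyl differ at all in this assay stays open, as the data show only one thing: the limit of > 200000 nM in this assay, at which 3 of the 3 values shown sit.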